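Swapping an isopropyl for pyridin-4-yl on a shared core

The source may report more compounds than this note shows. Statements on the series, on what has been measured and on what is new or still open speak of the compounds shown alone.

Of the compounds shown here, three built on one shared core have been measured in an ADME assay on the whole organism (plasma) for pharmacokinetics, with Rattus norvegicus as the target, with a stated time of 6 h, at a dose of 10 mg/kg by the oral route; on this read-out higher numbers stand for higher exposure at the dose given and lower numbers for lower exposure. Compound 1 `CNc1nc(C)c(-c2nc3ccccc3s2)c(N[C@@H]2C[C@H](CO)[C@@H](O)[C@H]2O)n1` gives 1080 ng.h/mL. Compound 2 `Cc1nc(NCC(C)C)nc(N[C@@H]2C[C@H](CO)[C@@H](O)[C@H]2O)c1-c1nc2ccccc2s1` gives 1020 ng.h/mL. Compound 3 `Cc1nc(NCc2ccccc2)nc(N[C@@H]2C[C@H](CO)[C@@H](O)[C@H]2O)c1-c1nc2ccccc2s1` gives 1050 ng.h/mL. Compound 2 thus sits alongside compound 1 and compound 3, with every gap among the three inside the usual scatter: a 1.1-fold lower number from compound 1 to compound 2 (0.02 log units; within the scatter), a 1.0-fold lower number from compound 1 to compound 3 (0.01 log units; within the scatter) and a 1.0-fold higher number from compound 2 to compound 3 (0.01 log units; within the scatter).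

Compound 4 `Cc1nc(NCc2ccncc2)nc(N[C@@H]2C[C@H](CO)[C@@H](O)[C@H]2O)c1-c1nc2ccccc2s1` is not yet measured. It differs from compound 2 in one place: pyridin-4-yl in place of isopropyl on a saturated chain carbon bound to a nitrogen on an aromatic ring. For the measured compounds named here, the step that bears most directly on this change is the one from compound 2 to compound 3, where phenyl replaces isopropyl at the same position and the outcome was a 1.0-fold higher number from compound 2 to compound 3 (0.01 log units; within the scatter). Pyridin-4-yl is also a six-membered aromatic ring entering in place of isopropyl, so that step is the closest guide available. Going by the values given here, no measured pair here speaks to the single nitrogen that pyridin-4-yl carries and phenyl does not, so that part of the change remains untested.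

On this basis compound 4 is expected to show no step beyond the scatter in this assay, with a 1.1-fold lower number from compound 2 to compound 4 (0.03 log units; within the scatter) as the estimated change. The estimated exposure for compound 4 is 950 ng.h/mL, with a range from 400 ng.h/mL to 2300 ng.h/mL.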

Compound 4, area under the concentration-time curve: 47.9 ng.h/mL
Estimate against measurement, compound 4: 20-fold (1.30 log units) above; measured number outside the range, below it.
By their numbers in this assay, from the lowest: compound 4; then compounds 2, 3 and 1 (each within the scatter of the next).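

For the compounds shown here, at this position, on a saturated chain carbon bound to a nitrogen on an aromatic ring, the earlier compounds gave the impression that this assay barely responds to what is attached: hydrogen, isopropyl and phenyl all gave numbers within the scatter of one another. Pyridin-4-yl ends that impression, with a 21-fold lower number from compound 2 to compound 4 (1.33 log units; beyond the scatter) and, against the smallest group of the set, a 23-fold lower number from compound 1 to compound 4 (1.35 log units; beyond the scatter) on the same read-out. The sharpest comparison is a 22-fold lower number from compound 3 to compound 4 (1.34 log units; beyond the scatter) between two groups that each bring one six-membered aromatic ring, and the entering ring holds one nitrogen where the leaving ring holds only carbon, which shows that a single atom in that ring can matter far more here than the whole step from hydrogen to phenyl did.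

Nothing among the data shown explains why the number drops. Going by these compounds, it also remains open whether a nitrogen placed elsewhere in this ring, or a dimethylamino group or a carboxylic acid at the same place, would give a drop of similar size.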